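Tetrazolyl for triazolyl on the cyano analogue

A few compounds are considered here, and "the series" means these few. Any claim that something is new, unique, unknown or untested is made for them only; others in the source may bear on it.

Measured so far:
Compound 1 `Cc1ccc(-c2cs/c(=N/NC(=O)CSc3nncn3C)n2-c2ccccc2)cc1` gives 39.6% in a functional assay on C6 cells (Rattus norvegicus) for cytotoxicity, read by MTT assay, with a stated time of 24 h, tested at 100 ug/mL; a lower number here means a stronger effect, a higher number a weaker effect of the compound at the concentration tested.
Compound 2 `Cc1ccc(-c2cs/c(=N/NC(=O)CSc3nnnn3C)n2-c2ccccc2)cc1` gives 39.7% in this assay.
Compound 3 `Cn1cnnc1SCC(=O)N/N=c1/scc(-c2ccc(C#N)cc2)n1-c1ccccc1` gives 55.2% in this assay.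

Compound 3 stands highest of the three numbers, its nearest neighbour being compound 2. Compound 4 `Cn1nnnc1SCC(=O)N/N=c1/scc(-c2ccc(C#N)cc2)n1-c1ccccc1` is not yet measured. It differs from compound 3 by 1-methyl-1H-tetrazol-5-yl in place of 4-methyl-4H-1,2,4-triazol-3-yl on a sulfur.

The same change is already covered once: a number 0.1 percentage points higher from compound 1 to compound 2 (within the scatter). That step was within the scatter, so no step beyond the scatter is expected here either, in either direction. The cyano-for-methyl step, a number 15.6 percentage points higher from compound 1 to compound 3 (beyond the scatter), does not bear on this change.

Compound 4 is therefore expected to show a number 0.2 percentage points lower from compound 3 to compound 4 (within the scatter) in this assay, giving an estimate of 55% with a range from 45% to 65%.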

Compound 4, a percentage reported as activity, at one concentration (the size of the read-out at that concentration, not a potency): 30.9%
Compound 4: middle estimate off by 24.1 percentage points, on the high side; the measured number lies below the stated range.
By their numbers in this assay, from the lowest: compounds 4, 1 and 2 (each within the scatter of the next); then compound 3.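

With cyano on the aromatic carbon, 1-methyl-1H-tetrazol-5-yl in place of 4-methyl-4H-1,2,4-triazol-3-yl on a sulfur gives a number 24.3 percentage points lower from compound 3 to compound 4 (beyond the scatter) in this assay. The outcome of this change therefore depends on the core: the same change on two cores in this assay, a number 0.1 percentage points higher (within the scatter) from compound 1 to compound 2 and a number 24.3 percentage points lower (beyond the scatter) from compound 3 to compound 4, 24.4 percentage points apart, beyond the scatter of two such steps. With the tetrazolyl group present, cyano in place of methyl gives a number 8.8 percentage points lower from compound 2 to compound 4 (within the scatter), so the shift seen with the triazolyl group does not carry over: the same change on two cores in this assay, a number 15.6 percentage points higher (beyond the scatter) from compound 1 to compound 3 and a number 8.8 percentage points lower (within the scatter) from compound 2 to compound 4, 24.4 percentage points apart, beyond the scatter of two such steps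

Going by these compounds, whether this dependence extends to other groups on the aromatic carbon, such as an amine or a carboxylic acid, remains open. Readings at a single concentration also speak only of a stronger or weaker effect at that concentration.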